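The source may hold more compounds than are shown below. What is called first, only, known or untested is meant among the compounds shown, and "the series" means these compounds.

The measured compounds in a functional assay on CCRF-CEM cells (Homo sapiens) for inhibition, read by cell counting, with a stated time of 3 days; a lower number here means a stronger inhibitor, a higher number a weaker inhibitor:

Compound 1, `Nc1cccc(-c2cn3c(-c4ccccc4)csc3n2)c1`, gives 29000 nM.
Compound 2, `COc1ccc(-c2csc3nc(-c4cccc(N)c4)cn23)cc1`, gives 6100 nM.
Compound 3, `COc1cccc(-c2nn3cc(-c4cccc(N)c4)nc3s2)c1`, reports > 250000 nM, which is a limit of the assay and not a number.

Compound 2 and compound 1 share one core and differ in a single place: hydrogen in place of methoxy on an aromatic carbon. In this assay that step is a 4.8-fold higher number from compound 2 to compound 1 (0.68 log units; beyond the scatter). Compound 3 stands at the limit of > 250000 nM in this assay, at which 1 of the 3 values shown sits. The difference between the core of compound 3 and the core of compound 2 is not broken down here.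

Compound 4, `Nc1cccc(-c2cn3nc(-c4ccccc4)sc3n2)c1`, has not yet been measured in this assay. It differs from compound 3 in one place: hydrogen in place of methoxy on an aromatic carbon. This is the same kind of change as from compound 2 to compound 1, but not the same change: in compound 2 the methoxy sits para to a large group, in compound 3 it sits meta to a large group, and the two pairs are built on different cores.

Since compound 3 already reports only a limit, compound 4 is expected to give a number no lower than that limit, and the step from compound 3 to compound 4 is estimated as a step that the limit leaves unreadable from compound 3 to compound 4, resting on compound 3 at the limit of > 250000 nM in this assay, at which 1 of the 3 values shown sits, and on the step of a 4.8-fold higher number from compound 2 to compound 1 (0.68 log units; beyond the scatter) that went toward a higher number. Compound 4 is therefore estimated at 400000 nM, with a range from 150000 nM to 1500000 nM, and most likely only a limit will be reported.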

Compound 4, half-maximal inhibitory concentration: 33000 nM
Beside the measured number, compound 4's estimate is 12-fold (1.08 log units) above it; measured number below the stated range.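

In this assay, hydrogen in place of methoxy gives an at least 7.5-fold lower number from compound 3 to compound 4 (0.87 log units; beyond the scatter) and so runs opposite to the change on the other core, which shows that neither the direction nor the size of this step carried over between these two cores: the same change on two cores in this assay, a 4.8-fold higher number (0.68 log units; beyond the scatter) from compound 2 to compound 1 and an at least 7.5-fold lower number (0.87 log units; beyond the scatter) from compound 3 to compound 4, at least 36-fold (1.55 log units) apart, beyond the scatter of two such steps. The figure for compound 3 is a limit of the assay and not a number, so the size of this step is only a bound, although its direction is still readable: the limit of > 250000 nM in this assay, at which 1 of the 4 values shown sits. What the two pairs do not show is what sets the steps apart, since the cores differ and the methoxy of compound 3 sits meta to a large group while that of compound 2 sits elsewhere, and with one pair on each core these two differences cannot be separated.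

The compounds shown leave open whether a methoxy at the same place on both cores would give steps that agree, and how an ethoxy, a hydroxyl or a fluorine there would compare on each core. They also leave open what an acetamide or a carboxylic acid in place of the amine would do on either core.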